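Removing the amino group from compound 1: what to expect

A few compounds are considered here, and "the series" means these few. Any claim that something is new, unique, unknown or untested is made for them only; others in the source may bear on it.

Compound 1 `COc1ccc(S(=O)(=O)N2CCc3cccc(-c4ccc(N)cc4)c32)cc1` is tested in a functional assay on HT-29 cells (Homo sapiens) for inhibition, with a stated time of 72 h (a lower number here means a stronger inhibitor, a higher number a weaker inhibitor), where compound 1 gives 301 nM. Among the three compounds measured so far, compound 1 stands second highest. The nearest neighbour is compound 2 `COc1ccc(S(=O)(=O)N2CCc3cccc(-c4ccc(N(C)C)cc4)c32)cc1`, which in this assay gives 467 nM; the step of a 1.6-fold higher number from compound 1 to compound 2 (0.19 log units; within the scatter) lies within the scatter, so the two cannot be told apart. The furthest is compound 3 `COc1ccc(S(=O)(=O)N2CCc3cccc(-c4cccnc4)c32)cc1`, which gives 76.3 nM; the step of a 3.9-fold lower number from compound 1 to compound 3 (0.60 log units; beyond the scatter) is a modest one beyond the scatter, and the step of a 6.1-fold lower number from compound 2 to compound 3 (0.79 log units; beyond the scatter) points the same way.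

Compound 4 `COc1ccc(S(=O)(=O)N2CCc3cccc(-c4ccccc4)c32)cc1` has not yet been measured. Its difference from compound 1 is hydrogen in place of amino on an aromatic carbon.

Within the data shown here, of the measured steps, only the one from compound 1 to compound 2 touches the same group, and there the amino group was altered rather than removed, with a step of a 1.6-fold higher number from compound 1 to compound 2 (0.19 log units; within the scatter) that stayed within the scatter. The steps to compound 3 exchange the whole ring and bear only loosely on this change. Taken together they suggest a small step, if any, probably towards a higher number. Compound 4 is therefore expected to give 450 nM, estimated between 150 nM and 1400 nM, a step of a 1.5-fold higher number from compound 1 to compound 4 (0.17 log units; within the scatter).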

Compound 4, half-maximal inhibitory concentration: 96.5 nM
Compound 4: the middle estimate sits 4.7-fold (0.67 log units) above what was measured; the measured number lies below the stated range.
By their numbers in this assay, from the lowest: compounds 3 and 4 (each within the scatter of the next); then compounds 1 and 2 (each within the scatter of the next).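

In this assay, the amino group of compound 1 proves to be no asset at its place on the aromatic ring: replacing it with hydrogen gives a modest gain in potency (a 3.1-fold lower number from compound 1 to compound 4 (0.49 log units; beyond the scatter)), and replacing the dimethylamino group does the same (a 4.8-fold lower number from compound 2 to compound 4 (0.68 log units; beyond the scatter)). The plain phenyl ring also changes how compound 3 reads, since the step from its pyridin-3-yl ring to phenyl cannot be told apart from scatter (a 1.3-fold higher number from compound 3 to compound 4 (0.10 log units; within the scatter)), so the ring nitrogen of compound 3 is not needed to reach this range. Among these four compounds, then, the two with a nitrogen substituent on the phenyl ring are the weaker pair, and no measurement is available here to explain why.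

From the compounds shown here alone, what remains open is whether this penalty belongs to amines alone or extends to other groups para to a large group, such as hydroxyl, methoxy or fluorine. The pyridin-3-yl and phenyl results also leave untested whether a ring nitrogen elsewhere, as in pyridin-4-yl, would read the same way.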